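The compounds below may be only part of what the source reports. "The series", "measured", "known", "first", "only" and "open" are said of these compounds alone.

Working notes on a small set of purine-type compounds read in a functional assay on HOP-92 cells (Homo sapiens) for cytotoxicity, read by sulforhodamine B assay, with a stated time of 48 h; on this read-out higher numbers stand for lower toxicity in this test and lower numbers for higher toxicity in this test.

For the measured compounds named here, compound 1 `ClCc1ccc(Cn2cnc3c(Cl)ncnc32)cc1` is the only member with a reported result. In this assay compound 1 gives > 100000 nM, and this is a limit of the assay rather than a number. The relevant line of the record is the limit of > 100000 nM in this assay, at which 1 of the 2 values shown sits.

Compound 2 `ClCc1ccccc1Cn1cnc2c(Cl)nc(Cl)nc21` carries a second chloro group on the shared core. In this assay compound 2 gives "not determined" (no result reported), so no single number places it anywhere. Going by the values given here, the only further value shown for the set is the one of compound 1, which is a limit of the assay. Compound 2 can therefore be set against nothing else.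

Compound 3 `ClCc1ccccc1Cn1cnc2c(Cl)ncnc21` differs from compound 2 by hydrogen in place of chloro on an aromatic carbon, the position lying between two ring nitrogen atoms. Among the compounds with values here, no step between measured compounds exists in this assay, so the size and direction of this change cannot be taken from the data; with the limit of compound 1 as the only reference, no shift beyond the scatter is expected.

For compound 3 in this assay the expected result is 100000 nM, with a range from 30000 nM to 300000 nM, and a limit report is considered likely.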

Compound 3, concentration lethal to 50% of the cells: 21400 nM
For compound 3 the middle estimate is 4.7-fold (0.67 log units) above the measured one, outside the stated range (below it).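

No step can be read from the result of compound 3 in this assay: compound 2, which differs from it in one place, offers no number to set against it. The compounds shown leave open how far hydrogen in place of chloro on this aromatic carbon, between two ring nitrogen atoms, shifts the result in this assay.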